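The compounds below may be only part of what the source reports. "The series", "measured", "known", "first", "only" and "open" are said of these compounds alone.

Of the compounds shown here, three built on a shared core have been measured so far in an ADME assay on the whole organism for pharmacokinetics, with Rattus norvegicus as the target; on this read-out higher numbers stand for wider distribution into tissues and lower numbers for narrower distribution. Compound 1 `O=S(=O)(c1ccc(O)c2ncccc12)C1CCCC1` gives 1.8 L/kg, compound 2 `O=S(=O)(c1ccc(C(F)(F)F)cc1)c1cc(F)c(O)c2ncccc12` gives 3.8 L/kg, and compound 3 `O=S(=O)(c1ccc(F)cc1)c1cc(Cl)c(O)c2ncccc12` gives 0.23 L/kg. Compound 3 therefore has the lowest number of the three, and both of the others stand clear of it, beyond the usual scatter of repeated measurements.

Compound 4 `O=S(=O)(c1ccc(F)cc1)c1cc(F)c(O)c2ncccc12` has not been measured yet. It differs from compound 3 in a single place: fluoro in place of chloro on an aromatic carbon. The halogen that changes sits ortho to a hydroxy group.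

Going by the values given here, no two measured compounds differ in just one place, so the data do not show directly what such a swap does in this assay. The nearest guide is compound 2, which also carries fluoro at this place and reaches 3.8 L/kg. It differs from compound 4 elsewhere as well, so it hints at a rise only weakly. A modest upward move, near the edge of the scatter, seems the most reasonable expectation. The expected change is a 2.2-fold higher number from compound 3 to compound 4 (0.34 log units; beyond the scatter). For compound 4 the estimated value is 0.5 L/kg, with an expected range from 0.2 L/kg to 1.5 L/kg.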

Compound 4, volume of distribution at steady state: 3.5 L/kg
Estimate against measurement, compound 4: 7.0-fold (0.85 log units) below; measured number above the stated range.
By their numbers in this assay, from the lowest: compound 3; then compounds 1, 4 and 2 (each within the scatter of the next, the first and the last beyond it).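

In this assay, the halogen ortho to a hydroxy group turns out to be a highly sensitive spot: fluoro in place of chloro gives a 15-fold higher number from compound 3 to compound 4 (1.18 log units; beyond the scatter) and is a large step for a swap of one heavy atom for another. The second single change, fluoro in place of trifluoromethyl on an aromatic carbon, gives a 1.1-fold lower number from compound 2 to compound 4 (0.04 log units; within the scatter) and so makes no readable difference in this pair, which places compound 4 level with compound 2 and shows that the earlier gap between compound 2 and compound 3 can be matched by the halogen swap alone. Nothing measured here explains why replacing chloro with fluoro has so large an effect on tissue distribution.

The compounds shown leave open whether bromo, methyl or an amine at this place would give a number close to that of compound 3 or close to that of compound 4. Going by these compounds alone, they also hold only one chloro and fluoro pair, so it remains unknown whether the step keeps its size when other parts of the molecule change.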